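Putting a 3-carboxypropyl chain on compound 2

A few compounds are considered here, and "the series" means these few. Any claim that something is new, unique, unknown or untested is made for them only; others in the source may bear on it.

Values in a functional assay on DU-145 cells (Homo sapiens) for cytotoxicity, read by trypan blue exclusion, with a stated time of 96 h; a higher number here means a weaker inhibitor, a lower number a stronger inhibitor:
Compound 1 `COc1cc(OC)c(/C=C/S(=O)(=O)Cc2ccc(OC)c(N)c2)c(OC)c1`: 4 nM
Compound 2 `COc1ccc(CS(=O)(=O)/C=C/c2c(OC)cc(O)cc2OC)cc1N`: 200 nM
Compound 3 `COc1ccc(CS(=O)(=O)/C=C/c2c(OC)cc(OCCCC(=O)O)cc2OC)cc1N`: not yet measured

Of the two measured compounds, compound 2 has the higher number, 200 nM, which makes it the weaker inhibitor in this assay. Compound 3 differs from it in one place: 3-carboxypropyl in place of hydrogen on an oxygen on an aromatic ring. In words, 3-carboxypropyl stands in place of hydrogen on an oxygen on an aromatic ring. Among the compounds with values here, only one measured step bears on this oxygen. Hydrogen in place of methyl there gave a 50-fold higher number from compound 1 to compound 2 (1.70 log units; beyond the scatter), a large step. Compound 3 again carries a carbon group on that oxygen, as compound 1 does at 4 nM, which hints at a lower number. However, a 3-carboxypropyl is not a methyl, and no measured compound here carries such a chain, so that one step cannot set a firm direction. No shift beyond the scatter is therefore expected, and the expected step is a 1.3-fold higher number from compound 2 to compound 3 (0.10 log units; within the scatter). For compound 3 the estimated value is 250 nM, with an expected range of 40 nM to 2000 nM.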

Compound 3, half-maximal inhibitory concentration: 25000 nM
For compound 3 the middle estimate is 100-fold (2.00 log units) below the measured one; measured number above the stated range.
By their numbers in this assay, from the lowest: compound 1; then compound 2; then compound 3.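

In this assay, within the data shown here, the earlier compounds showed only that hydrogen in place of methyl on this oxygen costs a great deal, which left open whether any carbon group there would restore the low number of compound 1. The new result answers that for one chain, since adding 3-carboxypropyl does not recover the loss but instead gives a 130-fold higher number from compound 2 to compound 3 (2.10 log units; beyond the scatter) and moves the number further from the methyl compound, with a 6300-fold higher number from compound 1 to compound 3 (3.80 log units; beyond the scatter) overall. So the position responds strongly to the identity of the group on the oxygen, not merely to whether that oxygen carries hydrogen or carbon, and nothing available explains why.

The 3-carboxypropyl group brings both a chain and a carboxylic acid, so these compounds cannot show which of the two accounts for the high number. A plain butyl chain, or the methyl ester of the same acid, would separate those two parts, while an ethyl group would test how far the group can grow beyond methyl on this oxygen.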